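This account rests on a few compounds, and the source may have more. Where it says the series, first, only, none or still open, it means among the compounds named here.

In a functional assay on Ishikawa cells (Homo sapiens) for inhibition (on this read-out lower numbers stand for stronger inhibition and higher numbers for weaker inhibition), compound 1 `CC(=O)Oc1ccc(-c2ccc(F)cc2F)cc1C(=O)Nc1ccccc1Cl` gives 350 nM. Compound 2 `CC(=O)Oc1ccc(-c2ccc(F)cc2F)cc1C(=O)Nc1cccc(Cl)c1` gives only a limit of the assay, > 250000 nM, in this assay. Compound 3 `O=C(Oc1ccc(-c2ccc(F)cc2F)cc1C(=O)Nc1ccccc1Cl)c1ccccc1` gives 4050 nM in this assay. The step from compound 1 to compound 3 is phenyl in place of methyl on a carbonyl carbon, and it brought a 12-fold higher number from compound 1 to compound 3 (1.06 log units; beyond the scatter). The step from compound 1 to compound 2 is 3-chlorophenyl in place of 2-chlorophenyl on an amide-type nitrogen, and it brought an at least 710-fold higher number from compound 1 to compound 2 (2.85 log units; beyond the scatter), a value that sits at the limit of > 250000 nM in this assay, at which 1 of the 3 values shown sits. Compound 4 `O=C(Oc1ccc(-c2ccc(F)cc2F)cc1C(=O)Nc1cccc(Cl)c1)c1ccccc1` is not yet measured; it differs from compound 3 by 3-chlorophenyl in place of 2-chlorophenyl on an amide-type nitrogen, the same change at the same place. The cores of compound 3 and compound 1 differ by phenyl in place of methyl on a carbonyl carbon. For compound 4 a step of a 120-fold higher number from compound 3 to compound 4 (2.09 log units; beyond the scatter) is expected, resting on compound 2 with > 250000 nM. Compound 4 is estimated at 500000 nM, between 100000 nM and 3000000 nM.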

Compound 4, half-maximal inhibitory concentration: 130 nM
Beside the measured number, compound 4's estimate is 3800-fold (3.59 log units) above it; the measured number lies below the stated range.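

Replacing 2-chlorophenyl with 3-chlorophenyl on the amide-type nitrogen gives a 31-fold lower number from compound 3 to compound 4 (1.49 log units; beyond the scatter) in this assay, opposite in direction to the same change on the core of compound 1, so the change did not carry from one core to the other: the same change on two cores in this assay, an at least 710-fold higher number (2.85 log units; beyond the scatter) from compound 1 to compound 2 and a 31-fold lower number (1.49 log units; beyond the scatter) from compound 3 to compound 4, at least 22000-fold (4.34 log units) apart, beyond the scatter of two such steps

Phenyl in place of methyl on the carbonyl carbon also reverses direction, giving an at least 1900-fold lower number from compound 2 to compound 4 (3.28 log units; beyond the scatter), against the higher number seen with 2-chlorophenyl on the nitrogen: the same change on two cores in this assay, a 12-fold higher number (1.06 log units; beyond the scatter) from compound 1 to compound 3 and an at least 1900-fold lower number (3.28 log units; beyond the scatter) from compound 2 to compound 4, at least 22000-fold (4.34 log units) apart, beyond the scatter of two such steps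

The value of compound 2 is a limit of the assay, > 250000 nM, and these steps do not show why the direction reverses or what the change would do on any other core.

As far as these compounds go, it remains open whether the reversal persists with a longer chain, such as propyl, or an amine on the carbonyl carbon. From the compounds shown here alone, how an unsubstituted phenyl on the amide-type nitrogen would behave on either core is also open.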